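Dimethylamino on the fused ring of compound 1

The source may hold more compounds than are shown below. What is called first, only, known or untested is meant among the compounds shown, and "the series" means these compounds.

Compound 1, `CCCS(=O)(=O)Nc1ccc(F)c(C(=O)Nc2cnc3[nH]ncc3c2)c1F`, gives 150 ug/mL in a physicochemical assay for solubility, read by HPLC, in phosphate buffer, with a stated time of 24 h, at pH 7.4; a higher number here means a more soluble compound, a lower number a less soluble compound.
Compound 2, `CCCS(=O)(=O)Nc1ccc(Cl)c(C(=O)Nc2cnc3[nH]ncc3c2)c1F`, gives 48 ug/mL in this assay.
Compound 3, `CCCS(=O)(=O)Nc1ccc(F)c(C(=O)Nc2cnc3[nH]cc(Br)c3c2)c1F`, gives < 1 ug/mL in this assay, which is a limit of the assay and not a number.

Among the two numbers shown, compound 1 stands highest; its nearest neighbour is compound 2, reached by a 3.1-fold lower number from compound 1 to compound 2 (0.49 log units; beyond the scatter) through chloro in place of fluoro on an aromatic carbon. The value of compound 3 is a limit, (the limit of < 1 ug/mL in this assay, at which 1 of the 3 values shown sits), and is treated here only as such.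

Compound 4, `CCCS(=O)(=O)Nc1ccc(F)c(C(=O)Nc2cnc3[nH]nc(N(C)C)c3c2)c1F`, differs from compound 1 by dimethylamino in place of hydrogen on an aromatic carbon. Among the measured compounds shown here, only one measured step exists, a 3.1-fold lower number from compound 1 to compound 2 (0.49 log units; beyond the scatter), and it concerns a halogen swap on the six-membered ring rather than a change on the fused ring system, so it bears on the present step only loosely. Compound 3 carries bromo on the fused ring and reports a limit, and no numbered step on that ring is available. Compound 4 is therefore expected to show a modest lowering in this assay relative to compound 1, a 2.5-fold lower number from compound 1 to compound 4 (0.40 log units; beyond the scatter). The estimate for compound 4 in this assay is 60 ug/mL, with a range from 15 ug/mL to 200 ug/mL.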

Compound 4, solubility: 450 ug/mL
For compound 4 the middle estimate is 7.5-fold (0.88 log units) below the measured one; measured number outside the range, above it.
By their numbers in this assay, from the lowest: compound 2; then compound 1; then compound 4. At a limit, below all of these: compound 3.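

In this assay, placing dimethylamino on this aromatic carbon of the five-membered aromatic ring gives a 3.0-fold higher number from compound 1 to compound 4 (0.48 log units; beyond the scatter), the only listed step at this ring, so the position can take a group of 3 heavy atoms without a loss in the read-out. The step runs the opposite way to the only other listed step, a 3.1-fold lower number from compound 1 to compound 2 (0.49 log units; beyond the scatter), which lies elsewhere on the molecule, so the two changes to compound 1 do not move the number in a shared direction. Nothing measured here accounts for the rise in compound 4, and the limit reported for compound 3 does not bear on it.

The compounds shown leave open whether the step belongs to dimethylamino in particular, since a primary amine, a morpholine ring, a methyl group or a longer carbon chain on the same carbon would be needed to separate the amine nitrogen from the added bulk. They also leave open whether dimethylamino would give a similar step on the chloro compound, compound 2, because the two changes appear together in no compound shown.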